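Swapping phenyl for methylpyrazolyl on the fused ring

The compounds below may be only part of what the source reports. "The series", "measured", "known", "first", "only" and "open" are said of these compounds alone.

Measured so far in a physicochemical assay for lipophilicity, at pH 7.4; on this read-out lower numbers stand for lower lipophilicity and higher numbers for higher lipophilicity:
compound 1 `COc1ccccc1-c1ccc(-c2nnc(N(C)Cc3ccc4nccn4c3)o2)cc1` gives 4.1;
compound 2 `Cc1cc(-c2c(C)nn(C)c2C)ccc1-c1nnc(N(C)Cc2ccc3nccn3c2)o1` gives 3.7;
compound 3 `Cc1cc(-c2c(C)nn(C)c2C)ccc1-c1nnc(N(C)Cc2ccc3ncc(-c4ccccc4)n3c2)o1` gives 5.3.

Compound 3 stands highest of the three numbers in this assay. Its value and that of compound 1, which gives 4.1, lie clearly apart, and the distance to compound 2 is larger still.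

Compound 4 `Cc1cc(-c2c(C)nn(C)c2C)ccc1-c1nnc(N(C)Cc2ccc3ncc(-c4cnn(C)c4)n3c2)o1` has not yet been measured. Its structure differs from compound 3 in one place: 1-methyl-1H-pyrazol-4-yl in place of phenyl on an aromatic carbon. The new group sits on an aromatic carbon of a five-membered aromatic ring with two nitrogen atoms, part of a fused system of two rings, next to the ring nitrogen.

For the measured compounds named here, one measured step bears on this change. The step of a number 1.60 log units higher from compound 2 to compound 3 (beyond the scatter) shows what adding the phenyl at that position did. Compound 4 keeps a six-atom aromatic group at the same place, but the entering 1-methyl-1H-pyrazol-4-yl carries two ring nitrogen atoms counted as hydrogen-bond acceptors, while the leaving phenyl carries none. A step downward from compound 3 is therefore expected, though a smaller one than removing the group altogether, and the expected change is a number 1.20 log units lower from compound 3 to compound 4 (beyond the scatter). The estimate for compound 4 in this assay is 4.1, with a range from 3.6 to 4.6.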

Compound 4, distribution coefficient: 4
Compound 4: the middle estimate sits 0.10 log units above what was measured; low and high end bracket the measured number.
By their numbers in this assay, from the lowest: compounds 2, 4 and 1 (each within the scatter of the next, the first and the last beyond it); then compound 3.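

In this assay, for the compounds shown here, the earlier compounds showed only that phenyl on this aromatic carbon goes with a large step up. Replacing it with 1-methyl-1H-pyrazol-4-yl gives a number 1.30 log units lower from compound 3 to compound 4 (beyond the scatter) and so takes back most of that step, even though the two groups have the same count of heavy atoms. Set against the compound with hydrogen at this carbon, the new group gives a number 0.30 log units higher from compound 2 to compound 4 (within the scatter) and so shows that this position can carry an added aromatic ring while the read-out stays within the scatter of compound 2. The entering group carries hydrogen-bond acceptors and the leaving group none, but nothing at hand shows whether that difference, the ring size or something else accounts for the result.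

Open, as far as these compounds go, is where other groups on this same carbon would fall, such as a pyridine ring, a morpholine or a plain methyl, relative to compound 2 and compound 3. Also open, from the compounds shown here alone, is whether the same swap of phenyl for 1-methyl-1H-pyrazol-4-yl would give a step of this size on a different core, such as the core of compound 1.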